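A Nitrile-Bearing Phenyl Replaces a Fluorophenyl

A few compounds are considered here, and "the series" means these few. Any claim that something is new, unique, unknown or untested is made for them only; others in the source may bear on it.

Of the compounds shown here, two have been measured in an assay on HEK293 cells for activation of Kir3.1/Kir3.2 (Homo sapiens), read by thallium flux; on this read-out lower numbers stand for smaller maximal responses and higher numbers for larger maximal responses. Compound 1 `Cc1cc(NC(=O)Cn2nnc(-c3ccccc3)n2)n(CC2CCCCC2)n1` gives 77%. Compound 2 `Cc1cc(NC(=O)Cn2nnc(-c3ccccc3F)n2)n(C2CCCCC2)n1` gives 88%, the higher of the two numbers, and its gap to compound 1 lies beyond the usual scatter. Compound 3 `Cc1cc(NC(=O)Cn2nnc(-c3cccc(C#N)c3)n2)n(C2CCCCC2)n1` has not been measured; it differs from compound 2 by 3-cyanophenyl in place of 2-fluorophenyl on an aromatic carbon. For the measured compounds named here, no measured pair shows a change of this kind, so the direction is open. The step of a number 8 percentage points lower from compound 2 to compound 3 (within the scatter) is expected to be small, at most a modest decrease. Compound 3 is estimated to reach 80%, with a likely range from 60% to 100%.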

Compound 3, largest response reached (Emax), in percent of the reference or control that the assay uses: 80%
Estimate against measurement, compound 3: no gap at the digits printed; low and high end bracket the measured number.
By their numbers in this assay, from the lowest: compounds 1, 3 and 2 (each within the scatter of the next, the first and the last beyond it).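

In this assay the change is a number 8 percentage points lower from compound 2 to compound 3 (within the scatter), so at this aromatic carbon 3-cyanophenyl, which brings a nitrile and a hydrogen-bond acceptor, gives a maximal response of similar size to 2-fluorophenyl. The swap alters both the substituent and its place on the phenyl ring, so this single step cannot separate the two. No evidence at hand explains the result.

Open, as far as these compounds go, is whether an amine or a carboxylic acid in place of the nitrile would keep a response of this size.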